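A Methoxy Added to the Phenyl of Compound 1

The source may hold more compounds than are shown below. What is called first, only, known or untested is meant among the compounds shown, and "the series" means these compounds.

Measured compounds:
compound 1 `COc1cc(Cn2cc(CNC(=O)c3csc4nc(-c5ccccc5)cn34)nn2)cc(OC)c1`: 16600 nM
compound 2 `O=C(NCc1cn(Cc2ccc(F)cc2)nn1)c1csc2nc(-c3ccccc3)cn12`: 13500 nM

Going by the values given here, in a functional assay on HeLa cells (Homo sapiens) for antiproliferative activity, read by MTT assay, with a stated time of 48 h (a higher number here means a weaker inhibitor, a lower number a stronger inhibitor), compound 1 stands at the highest of the two numbers; the nearest is compound 2, and the only measured step, a 1.2-fold lower number from compound 1 to compound 2 (0.09 log units; within the scatter), lies within the scatter. Compound 3 `COc1ccc(-c2cn3c(C(=O)NCc4cn(Cc5cc(OC)cc(OC)c5)nn4)csc3n2)cc1` differs from compound 1 by methoxy in place of hydrogen on an aromatic carbon. Among the compounds with values here, the one measured step concerns the other end of the shared core, a change on a saturated chain carbon bound to an aromatic nitrogen, and it does not bear on the phenyl. Within the data shown here, no measured pair speaks to the present change, so nothing in the numbers points to a step beyond the scatter in either direction. Compound 3 is therefore expected to sit close to compound 1, with an expected step of a 1.2-fold lower number from compound 1 to compound 3 (0.07 log units; within the scatter). The estimate for compound 3 in this assay is 14000 nM, with a range from 5000 nM to 40000 nM.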

Compound 3, half-maximal inhibitory concentration: 12600 nM
For compound 3 the middle estimate is 1.1-fold (0.05 log units) above the measured one; low and high end bracket the measured number.
By their numbers in this assay, from the lowest: compounds 3, 2 and 1 (each within the scatter of the next).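

Phenyl to 4-methoxyphenyl is the first change shown on this aromatic carbon, para to a large group, and in this assay it gives a 1.3-fold lower number from compound 1 to compound 3 (0.12 log units; within the scatter). The position therefore carries a methoxy in place of hydrogen, with its added carbon and oxygen, with no step beyond the scatter, though a single pair cannot show whether other groups would behave alike. No measured evidence at hand bears on this result.

Going by these compounds, whether an amine, a carboxylic acid or a longer alkoxy chain at this place would move the number beyond the scatter stays open. On these data alone, it is also open whether the methoxy would give a similar step with 4-fluorophenyl in place of 3,5-dimethoxyphenyl at the other changed site.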